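From 3-chloro-4-fluorophenyl to 3,5-dichlorophenyl on the shared core

This account rests on a few compounds, and the source may have more. Where it says the series, first, only, none or still open, it means among the compounds named here.

Compound 1 `N#Cc1cccc(Nc2ncnc3cc(NC(=O)/C=C/c4ccccc4)sc23)c1` gives 7220 nM
Compound 2 `O=C(/C=C/c1ccccc1)Nc1cc2ncnc(Nc3ccc(F)c(Cl)c3)c2s1` gives 2810 nM

In a functional assay on HeLa cells (Homo sapiens) for antiproliferative activity, read by MTT assay, with a stated time of 48 h (on this read-out higher numbers stand for weaker inhibition and lower numbers for stronger inhibition), compound 2 gives 2810 nM, the lower of the two numbers. Compound 3 `O=C(/C=C/c1ccccc1)Nc1cc2ncnc(Nc3cc(Cl)cc(Cl)c3)c2s1` has not yet been measured. It differs from compound 2 by 3,5-dichlorophenyl in place of 3-chloro-4-fluorophenyl on a nitrogen on an aromatic ring, with 3,5-dichlorophenyl in place of 3-chloro-4-fluorophenyl on a nitrogen on an aromatic ring. Going by the values given here, only one measured step bears on this, a 2.6-fold lower number from compound 1 to compound 2 (0.41 log units; beyond the scatter), made at the same place but with a different departing group. Since that step was modest, the change is expected to give no step beyond the scatter, and the estimated step is a 1.1-fold higher number from compound 2 to compound 3 (0.03 log units; within the scatter) in either direction. For compound 3 the estimated value is 3000 nM with an expected range of 1200 nM to 7500 nM overall.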

Compound 3, half-maximal inhibitory concentration: 3210 nM
The estimate for compound 3 lay 1.1-fold (0.03 log units) below the measured number; the measured number falls inside the stated range.
By their numbers in this assay, from the lowest: compounds 2 and 3 (each within the scatter of the next); then compound 1.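

In this assay, replacing 3-chloro-4-fluorophenyl with 3,5-dichlorophenyl on a nitrogen on an aromatic ring gives a 1.1-fold higher number from compound 2 to compound 3 (0.06 log units; within the scatter), so the two groups cannot be told apart here. The step of a 2.2-fold lower number from compound 1 to compound 3 (0.35 log units; beyond the scatter) shows that the difference from 3-cyanophenyl is not confined to 3-chloro-4-fluorophenyl but also holds for a second chlorinated phenyl. Nothing at hand explains these results.

The compounds shown leave open how an unsubstituted phenyl would compare at this position. They also leave open whether a phenyl carrying an amine or a carboxylic acid would keep these numbers.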